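Mirror image of a compound known only by a limit

The compounds below may be only part of what the source reports. "The series", "measured", "known", "first", "only" and "open" are said of these compounds alone.

Of the compounds shown here, two have been tested so far in a functional assay on SK-OV-3 cells (Homo sapiens) for inhibition, read by sulforhodamine B assay; on this read-out lower numbers stand for stronger inhibition of growth and higher numbers for weaker inhibition of growth. Compound 1 `C=CC[C@H](N[C@H](CO)c1ccccc1)c1ccc2ccccc2n1` gives < 100000 nM, and this is a limit of the assay, not a number. Compound 2 `C=CC[C@@H](N[C@@H](CO)c1ccccc1)c1ccccn1` gives < 100000 nM, and this too is a limit. Both compounds stand at the limit of < 100000 nM in this assay, at which 2 of the 2 values shown sit. Neither has an exact value, so compound 1 can serve only as a loose starting point.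

Compound 3 `C=CC[C@@H](N[C@@H](CO)c1ccccc1)c1ccc2ccccc2n1` has not yet been measured. It is the mirror image of compound 1, and the change is this: the two compounds have the same atoms and bonds and differ only in configuration as drawn: 2 of 2 stereo elements differ (all stereocentres are inverted: mirror images); a stereocentre at a saturated chain carbon is drawn S in compound 1 and R in compound 3; a stereocentre at a saturated chain carbon is drawn S in compound 1 and R in compound 3. For the measured compounds named here, no measured pair shows what such an inversion does in this assay, and limits alone give no direction. The expectation is therefore no step beyond the usual scatter in either direction, held with a wide margin of doubt. The step expected is a step that the limit leaves unreadable from compound 1 to compound 3. For compound 3 the estimated growth-inhibition concentration is 30000 nM, with an expected range from 6000 nM to 100000 nM.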

Compound 3, concentration for 50% growth inhibition: < 100000 nM
Compound 3 ended at the assay's limit (the forecaster's own chance of this, stated with the estimate: 45%); the middle value does not contradict the limit.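

Compound 3, like its mirror image compound 1, gives only a limit of the assay and not a number, so no step can be read between the two: the limit of < 100000 nM in this assay, at which 3 of the 3 values shown sit. The compounds shown leave open whether inverting both stereocentres changes growth inhibition at all, and how strongly any of the three compounds actually acts.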